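Aryl exchange on the triazole nitrogen of compound 3

The source may report more compounds than this note shows. Statements on the series, on what has been measured and on what is new or still open speak of the compounds shown alone.

Compound 3 `Cc1ccccc1-n1nncc1CN1C(=O)C2(C(C#N)=C(N)Oc3c(N)cc4nc5ccccc5nc4c32)c2ccccc21` is one of three compounds with the shared core that have been measured in an ADME assay on HUVEC cells (Homo sapiens) for antiproliferative activity, read by MTT assay, with a stated time of 48 h; a lower number here means a stronger inhibitor, a higher number a weaker inhibitor. In that assay compound 3 gives only a limit, > 50000 nM, and no number. Compound 1 `N#CC1=C(N)Oc2c(c3nc4ccccc4nc3c3ccccc23)C12C(=O)N(Cc1cnnn1-c1cccc(S(N)(=O)=O)c1)c1ccccc12` gives 38600 nM in this assay. Compound 2 `Cc1ccc(C)c(-n2nncc2CN2C(=O)C3(C(C#N)=C(N)Oc4c3c3nc5ccccc5nc3c3ccccc43)c3ccccc32)c1` likewise reaches only a limit, > 50000 nM. Among the compounds with values here, the single measured step that changes the aryl group on the aromatic nitrogen of the triazole, an at least 1.2-fold higher number from compound 1 to compound 2 (0.11 log units; that floor lies within the scatter), thus moves from a number to the limit, and its real size stays open because the limit of > 50000 nM in this assay, at which 2 of the 3 values shown sit, holds two of the three values.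

Compound 4 `N#CC1=C(N)Oc2c(N)cc3nc4ccccc4nc3c2C12C(=O)N(Cc1cnnn1-c1ccc(Cl)cc1)c1ccccc12` differs from compound 3 in the same place: 4-chlorophenyl in place of 2-methylphenyl on an aromatic nitrogen. Within the data shown here, no measured step compares a 2-methylphenyl with a 4-chlorophenyl, and the only aryl exchange available, from compound 1 to compound 2, offers merely a floor that lies within the scatter. Compound 3 already sits at the limit, so a measurable number would require a gain larger than anything shown. The expectation for compound 4 in this assay is therefore no step beyond the scatter, a number no higher from compound 3 to compound 4 (the limit leaves the size open), with another limit the likeliest outcome. Compound 4 is estimated at 50000 nM, between 20000 nM and 120000 nM.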

Compound 4, half-maximal inhibitory concentration: > 50000 nM
Compound 4 ended at the assay's limit; the forecaster's own chance of this, stated with the estimate: 70%; the middle value sits exactly at the limit.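

In this assay, within the data shown here, compound 3 and compound 4 both give only a limit and no number, so the exchange of 2-methylphenyl for 4-chlorophenyl yields no step that can be read. The compounds shown leave open the real size of any aryl exchange on the triazole nitrogen, with most values resting at one limit: the limit of > 50000 nM in this assay, at which 3 of the 4 values shown sit.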